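Cinnamamide series: trifluoromethyl added to compound 3

This account rests on a few compounds, and the source may have more. Where it says the series, first, only, none or still open, it means among the compounds named here.

Measured compounds:
- compound 1 `CN(C)CCC(NC(=O)/C=C/c1ccc(C(F)(F)F)cc1)c1ccc2ccccc2c1`: 135 nM
- compound 2 `CN(C)CCC(NC(=O)/C=C/c1ccc(C(F)(F)F)cc1)c1ccc(Cl)cc1`: 129 nM
- compound 3 `Cc1ccc(C(CCN(C)C)NC(=O)/C=C/c2ccccc2)cc1`: 1550 nM

In a functional assay on NIH3T3 cells for agonist activity at Urotensin-2 receptor (Homo sapiens), with a stated time of 5 days (on this read-out higher numbers stand for an effect only at larger amounts of compound and lower numbers for an effect already at smaller amounts), compound 3 gives 1550 nM, the highest of the three numbers, with compound 1 and compound 2 both well beyond the scatter from it. Compound 1 and compound 2 are within the scatter of each other: a 1.0-fold lower number from compound 1 to compound 2 (0.02 log units; within the scatter). Compound 3 differs from both of them in two places, in the group on the saturated chain carbon and in the absence of a trifluoromethyl on the cinnamoyl ring.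

Compound 4 `Cc1ccc(C(CCN(C)C)NC(=O)/C=C/c2ccc(C(F)(F)F)cc2)cc1` keeps the core of compound 3 and changes it in one place: trifluoromethyl in place of hydrogen on an aromatic carbon. Among the compounds with values here, no measured step has the same change alone, so the expectation rests on the gap between compound 3 and compound 1, which combines this change with the one from the step from compound 1 to compound 2 that stayed within the scatter. The trifluoromethyl is shared by compound 1 and compound 2, both of which sit far below compound 3. On that basis a decrease beyond the scatter is expected for this assay, of roughly a 6.2-fold lower number from compound 3 to compound 4 (0.79 log units; beyond the scatter). Compound 4 is estimated at 250 nM, within 100 nM to 700 nM.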

Compound 4, half-maximal effective concentration: 437 nM
The estimate for compound 4 lay 1.7-fold (0.24 log units) below the measured number; the range from low to high includes it.
By their numbers in this assay, from the lowest: compounds 2 and 1 (each within the scatter of the next); then compound 4; then compound 3.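

In this assay, trifluoromethyl in place of hydrogen on the aromatic carbon para to a large group accounts on its own for part of the earlier gap (a 3.5-fold lower number from compound 3 to compound 4 (0.55 log units; beyond the scatter)). With trifluoromethyl held constant, the aryl group on the saturated chain carbon still matters, since compound 4 stands apart from both chloro and naphthalen-2-yl partners (a 3.4-fold higher number from compound 2 to compound 4 (0.53 log units; beyond the scatter); a 3.2-fold higher number from compound 1 to compound 4 (0.51 log units; beyond the scatter)), though these two partners lie within the scatter of each other. No supporting evidence is available to explain any of these steps.

Open, as far as these compounds go, is whether a nitrile or a methoxy on the same aromatic carbon would give a step of similar size. Also open, from the compounds shown here alone, is whether the trifluoromethyl step keeps its size with 4-chlorophenyl or naphthalen-2-yl on the chain carbon.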